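The source may hold more compounds than are shown below. What is called first, only, known or untested is meant among the compounds shown, and "the series" means these compounds.

Measured in a functional assay on MCF7 cells (Homo sapiens) for antiproliferative activity, read by MTT assay, with a stated time of 48 h, tested at 50 uM; on this read-out lower numbers stand for a stronger effect and higher numbers for a weaker effect at the one concentration tested:
- compound 1 `OC(CCn1nc2c(Br)c(Br)c(Br)c(Br)c2n1)c1cccc(Br)c1`: 11%
- compound 2 `OC(CCn1nc2c(Br)c(Br)c(Br)c(Br)c2n1)c1ccc(F)cc1`: 7%
- compound 3 `OC(CCn1nc2c(Br)c(Br)c(Br)c(Br)c2n1)c1cccc(Cl)c1`: 12%

Compound 3 holds the highest of the three numbers, but its nearest neighbour is compound 1 at a number 1 percentage points higher from compound 1 to compound 3 (within the scatter) and its furthest is compound 2 at a number 5 percentage points higher from compound 2 to compound 3 (within the scatter), both within the scatter. Compound 4 `OC(CCn1nc2c(Br)c(Br)c(Br)c(Br)c2n1)c1ccccc1` differs from compound 3 by hydrogen in place of chloro on an aromatic carbon. Among the compounds with values here, the only step that bears on the halogen at that position is a number 1 percentage points higher from compound 1 to compound 3 (within the scatter), within the scatter; the aryl swaps a number 4 percentage points lower from compound 1 to compound 2 (within the scatter) and a number 5 percentage points higher from compound 2 to compound 3 (within the scatter) were likewise within the scatter. No step beyond the scatter is therefore expected in this assay . The step is estimated at a number 1 percentage points lower from compound 3 to compound 4 (within the scatter). Compound 4 is expected to give 11%, in the range 4% to 20%.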

Compound 4, a percentage reported as activity, at one concentration (the size of the read-out at that concentration, not a potency): 23%
Compound 4: middle estimate off by 12 percentage points, on the low side; measured number outside the range, above it.
By their numbers in this assay, from the lowest: compounds 2, 1 and 3 (each within the scatter of the next); then compound 4.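

In this assay the halogen on the phenyl ring matters in a way the swaps among halogens did not show: hydrogen in its place gives a number 11 percentage points higher from compound 3 to compound 4 (beyond the scatter), and the same change gives a number 12 percentage points higher from compound 1 to compound 4 (beyond the scatter) and a number 16 percentage points higher from compound 2 to compound 4 (beyond the scatter), each toward a weaker effect at the one concentration tested. Chloro, bromo and fluoro stay within the scatter of each other, yet all three stand apart from hydrogen, and no compound shown goes against this. Nothing available accounts for the change. Open, on these data alone, is whether a methoxy group or an amine on the ring would match the halogens or fall with hydrogen.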